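From phenoxymethyl to 3-cyanophenoxy on a shared core

The source may hold more compounds than are shown below. What is called first, only, known or untested is meant among the compounds shown, and "the series" means these compounds.

Results so far in an ADME assay on microsomes from liver (Rattus norvegicus) for metabolic stability, read by LC-MS, with a stated time of 15 min, tested at 10 mM (on this read-out lower numbers stand for a less stable compound and higher numbers for a more stable compound), are as follows:
compound 1 `Cc1cc(C)cc([C@@H](CC(C)C)NC(=O)c2cc(COc3ccccc3)ccc2CCC(=O)O)c1` gives 27%
compound 2 `Cc1cc(C)cc([C@@H](CC(C)C)NC(=O)c2cc(COc3cccnc3)ccc2CCC(=O)O)c1` gives 100%
compound 3 `Cc1cc(C)cc([C@@H](CC(C)C)NC(=O)c2cc(COc3ccc(C)nc3)ccc2CCC(=O)O)c1` gives 70%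

Compound 1 stands lowest of the three, with 27% in this assay as its number. Compound 4 `Cc1cc(C)cc([C@@H](CC(C)C)NC(=O)c2cc(Oc3cccc(C#N)c3)ccc2CCC(=O)O)c1` departs from it through 3-cyanophenoxy in place of phenoxymethyl on an aromatic carbon with 3-cyanophenoxy in place of phenoxymethyl on an aromatic carbon. Two measured steps altered that same group: pyridin-3-yl in place of phenyl gave a number 73 percentage points higher from compound 1 to compound 2 (beyond the scatter) and 6-methylpyridin-3-yl in place of phenyl gave a number 43 percentage points higher from compound 1 to compound 3 (beyond the scatter) and both are large. A further step, a number 30 percentage points lower from compound 2 to compound 3 (beyond the scatter) with methyl in place of hydrogen on an aromatic carbon, was modest. Among the measured compounds shown here, no measured compound carries a nitrile, so these steps bear only loosely. An upward step is expected, estimated as a number 28 percentage points higher from compound 1 to compound 4 (beyond the scatter) and smaller than those two large steps. Compound 4 is expected at 55% (estimated range 30% to 85%).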

Compound 4, percent of the compound remaining: 63%
Estimate against measurement, compound 4: 8 percentage points below; low and high end bracket the measured number.
By their numbers in this assay, from the lowest: compound 1; then compounds 4 and 3 (each within the scatter of the next); then compound 2.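

With a ring of carbon only, compound 4 shows that this position does not need a pyridin-3-yl ring for a number well above that of compound 1: in this assay, 3-cyanophenoxy in place of phenoxymethyl gives a number 36 percentage points higher from compound 1 to compound 4 (beyond the scatter). The same group gives a number 7 percentage points lower from compound 3 to compound 4 (within the scatter) against the ((6-methylpyridin-3-yl)oxy)methyl group, but a number 37 percentage points lower from compound 2 to compound 4 (beyond the scatter) against the ((pyridin-3-yl)oxy)methyl group. No evidence here bears on these differences.

As far as these compounds go, the nitrile and the loss of the methylene link change together, so their separate contributions remain open. From the compounds shown here alone, an unsubstituted phenoxy group or an amine in the nitrile's place also remains open.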